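Working notes: methoxy to 2-oxopyrrolidin-1-yl

The source may hold more compounds than are shown below. What is called first, only, known or untested is meant among the compounds shown, and "the series" means these compounds.

Values from a functional assay on MDA-MB-231 cells (Homo sapiens) for inhibition, read by sulforhodamine B assay, with a stated time of 74 h (on this read-out higher numbers stand for weaker inhibition and lower numbers for stronger inhibition), follow.
Compound 1 `Cc1ccc(S(=O)(=O)N2C(=O)COC23C=CC(=O)C=C3)cc1` gives 70 nM
Compound 2 `O=C1C=CC2(C=C1)OCC(=O)N2S(=O)(=O)c1ccccc1` gives > 10000 nM as a limit
Compound 3 `COc1ccc(S(=O)(=O)N2C(=O)COC23C=CC(=O)C=C3)cc1` gives > 10000 nM as a limit

Compound 3 stands with > 10000 nM in this assay and this is a limit, not a number. Compound 4 `O=C1C=CC2(C=C1)OCC(=O)N2S(=O)(=O)c1ccc(N2CCCC2=O)cc1` differs by 2-oxopyrrolidin-1-yl in place of methoxy on an aromatic carbon with 2-oxopyrrolidin-1-yl in place of methoxy on an aromatic carbon, para to a large group. Only compound 1 has a number here, and both replacements of its methyl give large steps beyond the scatter: an at least 140-fold higher number from compound 1 to compound 2 (2.15 log units; beyond the scatter) and an at least 140-fold higher number from compound 1 to compound 3 (2.15 log units; beyond the scatter). The remaining one, a step that the two limits leave unreadable from compound 2 to compound 3, tells nothing. A return to the level of compound 1 is therefore not expected, only a small move towards lower numbers at best. The expected step is an at least 1.6-fold lower number from compound 3 to compound 4 (0.22 log units; that floor lies within the scatter) as estimated. Compound 4 is estimated at 6000 nM with a range of 400 nM to 10000 nM and a report as a limit is about as likely.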

Compound 4, half-maximal inhibitory concentration: > 10000 nM
Compound 4: a limit, no number; the forecaster's own chance of this, stated with the estimate: 50%; middle value at least 1.6-fold (0.22 log units) from the limit.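

In this assay, a third replacement of the methyl of compound 1 now fails to keep its level, and this time the entering group is a larger ring, 2-oxopyrrolidin-1-yl, on the same aromatic carbon: the change gives an at least 140-fold higher number from compound 1 to compound 4 (2.15 log units; beyond the scatter). The value of compound 4, > 10000 nM, is a limit and not a number. The steps among compounds 2, 3 and 4 cannot be read, and the comparison stops at one shared level: the limit of > 10000 nM in this assay, at which 3 of the 4 values shown sit.

On these data alone, whether ethyl, chlorine or an amine at this position would hold the level of compound 1 stays open. As far as these compounds go, how compounds 2, 3 and 4 rank against one another also stays open.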